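The source may report more compounds than this note shows. Statements on the series, on what has been measured and on what is new or still open speak of the compounds shown alone.

Of the compounds shown here, two have numbers so far in a functional assay on L1210 cells (Mus musculus) for inhibition; a higher number here means a weaker inhibitor, a lower number a stronger inhibitor. Compound 1 `O=C1O/C(=C\Cn2cc(C(F)(F)F)c(=O)[nH]c2=O)C(OCc2ccccc2)=C1OCc1ccccc1` gives 2000 nM, and compound 2 `O=C1O/C(=C\Cn2cc(I)c(=O)[nH]c2=O)C(OCc2ccccc2)=C1OCc1ccccc1` gives 7500 nM, the highest of the two numbers. The next entry, compound 3 `O=C1O/C(=C\Cn2ccc(=O)[nH]c2=O)C(OCc2ccccc2)=C1OCc1ccccc1`, differs from compound 2 by hydrogen in place of iodo on an aromatic carbon. For the measured compounds named here, only one measured step bears on this place, a 3.8-fold higher number from compound 1 to compound 2 (0.57 log units; beyond the scatter), which is modest and beyond the scatter. That step exchanges one substituent for another, so it gives no direct measure of removing iodo, and the direction remains uncertain. A step no larger than that one is expected in this assay, leaning slightly towards a lower number and possibly within the scatter. The estimated step is a 1.5-fold lower number from compound 2 to compound 3 (0.18 log units; within the scatter). Compound 3 is estimated at 5000 nM, with an expected range of 1800 nM to 15000 nM.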

Compound 3, half-maximal inhibitory concentration: 12900 nM
Estimate against measurement, compound 3: 2.6-fold (0.41 log units) below; the measured number falls inside the stated range.
By their numbers in this assay, from the lowest: compound 1; then compounds 2 and 3 (each within the scatter of the next).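

In this assay, for the compounds shown here, replacing iodo with hydrogen gives the first direct reading of removing a substituent from this aromatic carbon (a 1.7-fold higher number from compound 2 to compound 3 (0.24 log units; within the scatter)), so hydrogen and iodo cannot be told apart here. Trifluoromethyl now stands apart from both groups (a 3.8-fold higher number from compound 1 to compound 2 (0.57 log units; beyond the scatter); a 6.5-fold higher number from compound 1 to compound 3 (0.81 log units; beyond the scatter)), which makes compound 1 the strongest inhibitor of the three, and this place matters for the trifluoromethyl group rather than for substitution as such. Nothing available explains this separation.

The compounds shown leave open whether the lower number of compound 1 is particular to trifluoromethyl or would be shared by a nitrile or a fluoro group at this place. They also leave open how an amine or a longer chain there would read in this assay.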